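This account rests on a few compounds, and the source may have more. Where it says the series, first, only, none or still open, it means among the compounds named here.

Compound 1 `CC(C)[C@H]1CC[C@@](O)(CO)[C@H]2C(=O)OCC(C(=O)O)=C[C@H]12`: > 32000 nM
Compound 2 `CC(C)[C@H]1CC[C@@](O)(CCl)[C@H]2C(=O)OCC(C(=O)O)=C[C@H]12`: 550 nM

Both results come from a functional assay on WM 266-4 cells (Homo sapiens) for inhibition, with a stated time of 72 h; on this read-out lower numbers stand for stronger inhibition and higher numbers for weaker inhibition. The value for compound 1 is a limit of the assay, not a number (the limit of > 32000 nM in this assay, at which 1 of the 2 values shown sits). Compound 1 thus stands at the weak end of what this assay can report, and its true potency could lie anywhere beyond that limit. Among the compounds with values here, the only measured step, an at least 58-fold lower number from compound 1 to compound 2 (1.76 log units; beyond the scatter), concerns chloro in place of hydroxy on a saturated chain carbon bound to a saturated ring carbon.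

Compound 3 `CNC(=O)C1=C[C@@H]2[C@@H](C(C)C)CC[C@@](O)(CO)[C@H]2C(=O)OC1` changes compound 1 at a different place: methylamino in place of hydroxy on a carbonyl carbon, which cut one bond further out reads carboxy to methylcarbamoyl. The hydroxy chain of compound 1, where compound 2 shows the series can gain, is left unchanged. Within the data shown here, no measured step touches the carbonyl carbon, so the step in hand gives no guide to this change, in either direction.

The expectation for compound 3 is therefore held near the starting point, with a wide range: compound 3 is expected at 30000 nM (range 4000 nM to 200000 nM). The expected step, an at least 1.0-fold lower number from compound 1 to compound 3 (0.02 log units; that floor lies within the scatter), is none beyond the scatter, with a fair chance that this assay again reports only a limit.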

Compound 3, half-maximal inhibitory concentration: > 32000 nM
Compound 3: a limit, no number (the forecaster's own chance of this, stated with the estimate: 60%); middle value at least 1.0-fold (0.02 log units) from the limit.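

Compound 3 gives > 32000 nM in this assay, a limit of the assay and not a number. Compound 1 also stands at a limit, so no step can be read between compound 1 and compound 3. The compounds shown leave open whether methylcarbamoyl in place of carboxy changes inhibition at all, with either the hydroxy chain or the chloro chain.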